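What the sulfonyl sulfur carries and the unbound share

The compounds below may be only part of what the source reports. "The series", "measured", "known", "first", "only" and "open" are said of these compounds alone.

Measured so far in an ADME assay on a cell-free system (plasma, Mus musculus) for protein binding, read by LC-MS, with a stated time of 4 h, tested at 5 uM (a higher number here means a larger unbound share of the compound, a lower number a smaller unbound share), on these compounds:
compound 1 `Nc1ccc(CNC(=O)Nc2ccc(S(=O)(=O)c3ccccc3)cc2)cn1` gives 0.027
compound 2 `C[C@@H]1CN(S(=O)(=O)c2ccc(NC(=O)NCc3cccnc3)cc2)C[C@H](C)O1` gives 0.011
compound 3 `O=C(NCc1cccnc1)Nc1ccc(S(=O)(=O)N2CCC3(CCNC3)CC2)cc1` gives 0.43

Compound 3 has the highest number of the three, and compound 1 and compound 2 both lie beyond the scatter below it. The next compound, compound 4 `CC1CNCCN(S(=O)(=O)c2ccc(NC(=O)NCc3cccnc3)cc2)C1`, alters only the group on the sulfonyl sulfur (a group of 8 heavy atoms (6 carbon, 2 nitrogen; one seven-membered non-aromatic ring with 2 hetero atoms) in place of a group of 10 heavy atoms (8 carbon, 2 nitrogen; one five-membered non-aromatic ring with 1 hetero atom, one six-membered non-aromatic ring with 1 hetero atom), on a sulfonyl sulfur), and it has not yet been measured.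

Within the data shown here, one measured step bears on this place: a 39-fold higher number from compound 2 to compound 3 (1.59 log units; beyond the scatter), a large change. So the group on the sulfur can matter greatly in this assay. Yet compound 2, at 0.011, carries oxygen in that group, whereas the groups in compound 3 and compound 4 hold only carbon and nitrogen. A single step cannot say how a seven-membered ring will behave, so a shift beyond the scatter is not expected. The expected size is a 1.1-fold lower number from compound 3 to compound 4 (0.05 log units; within the scatter), a slightly lower number at most within the scatter. Compound 4 is estimated at 0.38, with an expected range from 0.18 to 0.65 on this read-out.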

Compound 4, unbound fraction: 0.39
Compound 4: middle estimate off by 1.0-fold (0.01 log units), on the low side; low and high end bracket the measured number.
By their numbers in this assay, from the lowest: compound 2; then compound 1; then compounds 4 and 3 (each within the scatter of the next).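

In this assay, the step of a 1.1-fold lower number from compound 3 to compound 4 (0.04 log units; within the scatter) shows that the group on the sulfonyl sulfur can change from two joined rings to one seven-membered ring with 2 hetero atoms without a change beyond the scatter. The step of a 35-fold higher number from compound 2 to compound 4 (1.55 log units; beyond the scatter) is a second large step from compound 2, so among these three compounds the two groups holding only carbon and nitrogen stand together, and the oxygen-bearing group of compound 2 stands apart. Nothing measured here explains this gap.

On these data alone, the group in compound 2 differs from the other two in its ring as well as its atoms, so the part played by the oxygen itself stays open. A plain piperazine ring or an unsubstituted morpholine ring on the sulfur would separate these two features.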